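The compounds below may be only part of what the source reports. "The series", "measured", "known", "first", "only" and "open" are said of these compounds alone.

Working notes on the hydroxamic acid series. Compound 1 `O=C(NO)[C@H]1CC(CC(=O)N2CCCC2)CN[C@@H]1C(=O)N1CC=C(c2ccccc2)CC1` gives 17 nM in an assay on isolated protein for inhibition of disintegrin and metalloproteinase domain-containing protein 10 (Homo sapiens); on this read-out higher numbers stand for weaker inhibition and lower numbers for stronger inhibition. Among the measured compounds shown here, compound 2 `CN(C(=O)c1ccccc1)C1CN[C@H](C(=O)N2CC=C(c3ccccc3)CC2)[C@@H](C(=O)NO)C1` gives 12 nM in this assay; the single measured one-site step, a 1.4-fold lower number from compound 1 to compound 2 (0.15 log units; within the scatter), lies in a different part of the shared core and does not exceed the scatter. Compound 3 `CN1C[C@@H](OC(=O)N2CCCCC2)C[C@H](C(=O)NO)[C@H]1C(=O)N1CCN(c2ccccc2)CC1` gives 9.6 nM in this assay. Its number sits with those of compound 2 and compound 1, both gaps being within the scatter, so no ordering among the three is claimed.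

Compound 4 `CN1C[C@@H](OC(=O)N2CCCCCC2)C[C@H](C(=O)NO)[C@H]1C(=O)N1CCN(c2ccccc2)CC1` differs from compound 3 by azepan-1-yl in place of piperidin-1-yl on a carbonyl carbon. For the measured compounds named here, no measured step bears on this position; the only measured step concerns a different substituent and was itself within the scatter, so nothing seen so far points to a shift in either direction. Compound 4 is therefore expected to stay close to compound 3, with a 1.0-fold higher number from compound 3 to compound 4 (0.02 log units; within the scatter) expected to remain within the scatter. The estimate for compound 4 in this assay is 10 nM, with a range of 4 nM to 28 nM.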

Compound 4, half-maximal inhibitory concentration: 35 nM
For compound 4 the middle estimate is 3.5-fold (0.54 log units) below the measured one; the measured number lies above the stated range.
By their numbers in this assay, from the lowest: compounds 3, 2 and 1 (each within the scatter of the next); then compound 4.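

In this assay, among the compounds shown here, the group on this carbonyl carbon is not a silent position: azepan-1-yl in place of piperidin-1-yl gives a 3.6-fold higher number from compound 3 to compound 4 (0.56 log units; beyond the scatter) and this modest step is the first one beyond the scatter. On this read-out the seven-membered ring therefore goes with weaker inhibition than the six-membered ring, at least on the core shared by compound 3 and compound 4. No data bearing on the origin of this step are at hand, so it stands as an observation only.

Going by these compounds, with just these two rings at the position, it remains open whether the trend continues with ring size or reflects something specific to azepan-1-yl. On these data alone, how a morpholin-4-yl or an open-chain diethylamino group on this carbonyl carbon would read also remains open.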